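Benzoyl to phenylsulfanyl on the shared core

The compounds below may be only part of what the source reports. "The series", "measured", "known", "first", "only" and "open" are said of these compounds alone.

Compound 1 `O=C(Nc1nc2cc(C(=O)c3ccccc3)ccc2[nH]1)OC1COC1` is the reference point. Among the measured compounds shown here, in a functional assay on PC-3 cells (Homo sapiens) for cytotoxicity, read by MTT assay, with a stated time of 72 h, tested at 10 uM (a higher number here means a weaker effect of the compound at the concentration tested, a lower number a stronger effect), compound 1 gives 65.6%, the second highest of the three numbers so far. The nearest neighbour is compound 2 `COC(=O)Nc1nc2cc(C(=O)c3ccccc3N(C)C3COC3)ccc2[nH]1`, which in this assay gives 54.8%, a number beyond the scatter lower. The furthest is compound 3 `CCCSc1ccc2[nH]c(NC(=O)OC3COC3)nc2c1`, which in this assay gives 84.5%.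

The step to compound 4 `O=C(Nc1nc2cc(Sc3ccccc3)ccc2[nH]1)OC1COC1` is phenylsulfanyl in place of benzoyl on an aromatic carbon. For the measured compounds named here, one measured step bears on it: a number 18.9 percentage points higher from compound 1 to compound 3 (beyond the scatter), where benzoyl also left and a sulfanyl group also entered, though the group that entered there was propylsulfanyl rather than phenylsulfanyl. That step was a modest rise in the number, that is a weaker effect. The change to compound 4 keeps the aromatic ring of the benzoyl and swaps only the link, so a rise in the same direction but of smaller size is expected in this assay, with no strong basis for a change beyond the scatter.

Compound 4 is therefore estimated at 74% in this assay, in a range from 58% to 90%, which means an expected step of a number 8.4 percentage points higher from compound 1 to compound 4 (within the scatter).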

Compound 4, a percentage reported as activity, at one concentration (the size of the read-out at that concentration, not a potency): 87.8%
Compound 4: the middle estimate sits 13.8 percentage points below what was measured; the range from low to high includes it.
By their numbers in this assay, from the lowest: compound 2; then compound 1; then compounds 3 and 4 (each within the scatter of the next).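

Phenylsulfanyl in place of benzoyl gives a number 22.2 percentage points higher from compound 1 to compound 4 (beyond the scatter) in this assay, so keeping an aromatic ring at this position does not hold the effect of compound 1 once a sulfur link replaces the carbonyl. Phenyl in place of propyl on the sulfur gives a number 3.3 percentage points higher from compound 3 to compound 4 (within the scatter), so the two groups on sulfur cannot be told apart here. Nothing available accounts for either step.

Still open, going by these compounds, is whether the step follows from the loss of the carbonyl or from the entry of sulfur, a question that an ether oxygen or a methylene link to the same phenyl could separate. Also open, on these data alone, is how an amine or a carboxylic acid on that phenyl ring would read in this assay.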